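The source may hold more compounds than are shown below. What is called first, only, known or untested is meant among the compounds shown, and "the series" means these compounds.

Compound 3 `Cc1ccc2c(NCc3ccc(NC(=O)C4CCN(C(=O)OC(C)(C)C)CC4)cc3)nc(N(C)C)nc2c1` has only a limit in a functional assay on SV5A8 cells (Homo sapiens) for cytotoxicity; a higher number here means a weaker inhibitor, a lower number a stronger inhibitor: in that assay compound 3 gives > 4820 nM, which is a limit of the assay rather than a number. Compound 1 `Cc1ccc2c(NCc3ccc(NC(=O)C4CCN(Cc5ccc(F)cc5)CC4)cc3)nc(N(C)C)nc2c1` also reaches only a limit, as compound 1 gives > 4820 nM in this assay. Compound 2 `CCCCN1CCC(C(=O)Nc2ccc(CNc3nc(N(C)C)nc4cc(C)ccc34)cc2)CC1` likewise gives > 10500 nM in this assay, again a limit. The three compounds share one core and differ only in the group on the amine nitrogen in the six-membered non-aromatic ring. The step that the two limits leave unreadable from compound 1 to compound 2, the step that the two limits leave unreadable from compound 1 to compound 3 and the step that the two limits leave unreadable from compound 2 to compound 3 all stay unreadable, since the limit of > 4820 nM in this assay, at which 2 of the 3 values shown sit, and the limit of > 10500 nM in this assay, at which 1 of the 3 values shown sits, hold every value shown. Compound 4 `Cc1ccc2c(NCc3ccc(NC(=O)C4CCN(Cc5ccco5)CC4)cc3)nc(N(C)C)nc2c1` carries a different group at that same nitrogen: (furan-2-yl)methyl in place of tert-butoxycarbonyl on an amine nitrogen in a ring. Among the measured compounds shown here, no measured step shows that a change at this position moves potency out of the limit region, so the step that the limit leaves unreadable from compound 3 to compound 4 is expected to stay small or unreadable. Compound 4 is therefore estimated at 9000 nM in this assay, with a range from 3000 nM to 30000 nM, and most likely again reported only as a limit.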

Compound 4, half-maximal inhibitory concentration: > 20000 nM
Compound 4: a limit, no number; the forecaster's own chance of this, stated with the estimate: 75%; middle value at least 2.2-fold (0.34 log units) away from the limit.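

Compound 4, like compound 1, compound 2 and compound 3, gives only a limit in this assay, so none of the steps between them can be read. The compounds shown leave open whether any group on this amine nitrogen would give an actual number in this assay.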